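This account rests on a few compounds, and the source may have more. Where it says the series, first, only, none or still open, it means among the compounds named here.

Within the data shown here, in a functional assay on HCT-116 cells (Homo sapiens) for inhibition, read by sulforhodamine B assay, with a stated time of 48 h, tested at 50 uM (on this read-out lower numbers stand for less inhibition of growth and higher numbers for more inhibition of growth at the one concentration tested), compound 2 `COc1cc2c(cc1CC=C(C)C)C(=O)C[C@@H](c1ccc(Oc3ccc(F)cc3)cc1)O2` gives 29% and stands lowest of the three compounds measured so far. Compound 1 `COc1ccc([C@@H]2C/C(=N/OCc3cn(-c4ccc(C(=O)c5ccccc5)cc4)nn3)c3cc(CC=C(C)C)c(OC)cc3O2)cc1` reaches 52% and compound 3 `COc1cc2c(cc1CC1OC1(C)C)C(=O)C[C@@H](c1ccc(O)cc1)O2` reaches 97% and both lie beyond the scatter above compound 2. These three differ in several places at once, so they do not show what any single change does. Compound 4 `CCOc1ccc([C@@H]2CC(=O)c3cc(CC=C(C)C)c(OC)cc3O2)cc1` differs from compound 2 in one place (ethyl in place of 4-fluorophenyl on an oxygen on an aromatic ring), where 4-fluorophenoxy becomes ethoxy. Among the measured compounds shown here, no measured pair shows the effect of this swap, so any forecast is rough. Compound 2 starts low at 29% and the other two measured compounds lie higher, so a move upward seems likelier than a move downward. The expected step in this assay is modest and upward, estimated as a number 11 percentage points higher from compound 2 to compound 4 (beyond the scatter) and possibly no larger than the scatter. For compound 4 the estimated value is 40% within an expected range of 18% to 70% here.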

Compound 4, percent growth inhibition at one concentration: 65%
Estimate against measurement, compound 4: 25 percentage points below; measured number inside the range.
By their numbers in this assay, from the lowest: compound 2; then compound 1; then compound 4; then compound 3.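

In this assay, among these compounds, putting ethyl in place of 4-fluorophenyl on the oxygen gives a number 36 percentage points higher from compound 2 to compound 4 (beyond the scatter) and is the first single change whose effect can be read, so the group on this oxygen clearly bears on growth inhibition at the one concentration tested. Here the pair with the ring and fluorine removed, and fewer heavy atoms in the group, gives the higher number, but this one pair cannot separate the loss of the ring, the loss of the fluorine and the change in atom count. Nothing measured here gives a reason for the step.

As far as these compounds go, whether plain phenyl, without the fluorine, would behave like 4-fluorophenyl or like ethyl remains open. So does the outcome with a longer chain such as butyl, or with a chain ending in an amine, on the same oxygen.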